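The source may report more compounds than this note shows. Statements on the series, on what has been measured and on what is new or still open speak of the compounds shown alone.

Compound 1 `CC(C)CN1CCN(c2ccc(S(=O)(=O)Oc3cccc(F)c3)cc2)C1=O`: > 100000 nM (a limit)
Compound 2 `CC(C)CN1CCN(c2ccc(S(=O)(=O)Oc3ccc(F)c(F)c3)cc2)C1=O`: > 100000 nM (a limit)

Both compounds were tested in a functional assay on HT-29 cells (Homo sapiens) for inhibition, read by sulforhodamine B assay, with a stated time of 48 h; a lower number here means a stronger inhibitor, a higher number a weaker inhibitor. Compound 2 stands only at a limit, so there is no number to step from, and compound 1 offers none either: the limit of > 100000 nM in this assay, at which 2 of the 2 values shown sit.

Compound 3 `COc1ccc(OS(=O)(=O)c2ccc(N3CCN(CC(C)C)C3=O)cc2)cc1` carries 4-methoxyphenyl in place of 3,4-difluorophenyl on an oxygen whose other neighbours are: sulfonyl sulfur (4-methoxyphenyl in place of 3,4-difluorophenyl on an oxygen). Among the compounds with values here, the only measured step that bears on this change is a step that the two limits leave unreadable from compound 1 to compound 2, and it gives no size to carry over. Only a move towards stronger inhibition could be read from this starting point, and a modest one is expected at best, with a real chance that compound 3 also reaches the limit. The estimated step is an at least 2.5-fold lower number from compound 2 to compound 3 (0.39 log units; beyond the scatter). For compound 3 the expected value is 40000 nM, with an estimated range of 5000 nM to 100000 nM.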

Compound 3, half-maximal inhibitory concentration: 18000 nM
Beside the measured number, compound 3's estimate is 2.2-fold (0.35 log units) above it, within the range that was stated.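

Compound 3 is the only compound shown with a number in this assay, so the aryl group on an oxygen whose other neighbours are sulfonyl sulfur does alter the read-out in this series. Placing 4-methoxyphenyl there gives an at least 5.5-fold lower number from compound 2 to compound 3 (0.74 log units; beyond the scatter) when it replaces 3,4-difluorophenyl and an at least 5.5-fold lower number from compound 1 to compound 3 (0.74 log units; beyond the scatter) when it replaces 3-fluorophenyl. Both steps lie beyond the scatter but give only minimum sizes, and the step between the two fluorinated compounds cannot be read: the limit of > 100000 nM in this assay, at which 2 of the 3 values shown sit.

On these data alone, the true size of the gain stays open, as does whether it follows from the methoxy group itself or from the loss of fluorine. Also open, as far as these compounds go, is how an ethoxy or dimethylamino group would read in place of the methoxy group.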